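A few compounds are considered here, and "the series" means these few. Any claim that something is new, unique, unknown or untested is made for them only; others in the source may bear on it.

Measured so far:
compound 1 `O=c1ccc2ccc(OCc3cn(-c4cccc(S(=O)(=O)N5CCc6ccccc6C5)c4)nn3)cc2o1`: 14%
compound 2 `O=c1cc(OCc2cn(-c3ccc(S(=O)(=O)N4CCc5ccccc5C4)cc3)nn2)c2ccccc2o1`: 14%
compound 3 `COc1cc2c(cc1OC)CN(S(=O)(=O)c1ccc(-n3cc(COc4cc(C=O)ccc4OC)nn3)cc1)CC2`: 14%

In an assay on isolated protein for inhibition of Aromatase (Homo sapiens), read by fluorescence, with a stated time of 10 min, tested at 12.5 uM (on this read-out higher numbers stand for more inhibition at the one concentration tested (going by the name of the read-out) and lower numbers for less inhibition), compound 1 gives 14%, compound 2 gives 14% and compound 3 gives 14%. Compound 3 therefore stands level with compounds 1 and 2 at the digits shown; the three values lie within the usual scatter of one another, so no order among them can be drawn from these numbers.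

Compound 4 `COc1cc2c(cc1OC)CN(S(=O)(=O)c1ccc(-n3cc(COc4ccccc4C)nn3)cc1)CC2` differs from compound 3 in one place: 2-methylphenyl in place of 5-formyl-2-methoxyphenyl on an oxygen on a saturated carbon. Going by the values given here, no step between two measured compounds is available to size this change, and the three measured values do not separate. With that, the expectation for this assay is no shift beyond the scatter. The step from compound 3 to compound 4 is expected to be no change at the digits printed from compound 3 to compound 4 (within the scatter). Compound 4 is estimated at 14%, within a range of 3% to 27%.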

Compound 4, a percentage reported as inhibition, at one concentration (the size of the read-out at that concentration, not a potency): 14%
Compound 4: middle estimate and measured number agree at the digits printed; measured number inside the range.
By their numbers in this assay, from the lowest: compounds 1, 2, 3 and 4 (each within the scatter of the next).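

In this assay, going by these compounds alone, this position gives the first paired reading: no change at the digits printed from compound 3 to compound 4 (within the scatter). The swap of 5-formyl-2-methoxyphenyl for 2-methylphenyl takes the group from 10 heavy atoms to 7 and from 2 hydrogen-bond acceptors to 0, yet the read-out at the one concentration tested does not separate the pair. No supporting data bear on this result. Open, going by these compounds, is whether an amine or a carboxylic acid on this phenyl ring would move the read-out beyond the scatter. Also open, on these data alone, is whether a longer chain in place of the methyl would do so.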